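Benzylidene penicillanate series: fluorinated aryl ketone, cytotoxicity estimate

The compounds below may be only part of what the source reports. "The series", "measured", "known", "first", "only" and "open" are said of these compounds alone.

The series shares one core, shown for compound 1 as `CC1(C)S[C@@H]2/C(=C\C(=O)c3ccc4ccccc4c3)C(=O)N2[C@H]1C(=O)OC(c1ccccc1)c1ccccc1`. In a functional assay on OE19 cells (Homo sapiens) for cytotoxicity, read by MTT assay, with a stated time of 48 h (a lower number here means a stronger inhibitor, a higher number a weaker inhibitor), compound 1 gives 19500 nM. Compound 2, `CC1(C)S[C@@H]2/C(=C\C(=O)c3ccccc3)C(=O)N2[C@H]1C(=O)OC(c1ccccc1)c1ccccc1`, gives in this assay 12800 nM. Of the two numbers measured, compound 2 gives the lower one, but the step of a 1.5-fold lower number from compound 1 to compound 2 (0.18 log units; within the scatter) lies within the scatter, so no order between the two compounds is established.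

Compound 3, `CC1(C)S[C@@H]2/C(=C\C(=O)c3cc(F)cc(F)c3)C(=O)N2[C@H]1C(=O)OC(c1ccccc1)c1ccccc1`, has not yet been measured in this assay. It differs from compound 2 in one place: 3,5-difluorophenyl in place of phenyl on a carbonyl carbon. Within the data shown here, the only measured step that bears on it is the exchange of one aryl group for another on the same carbonyl carbon, a 1.5-fold lower number from compound 1 to compound 2 (0.18 log units; within the scatter), which did not move the number beyond the scatter. Among the measured compounds shown here, no measured step speaks to fluorine on that ring. The expectation is therefore a step of no change at the digits printed from compound 2 to compound 3 (within the scatter) in this assay, that is, none beyond the scatter in either direction. On that basis compound 3 is estimated at 12800 nM, with a range from 5000 nM to 32000 nM.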

Compound 3, half-maximal inhibitory concentration: 17600 nM
Beside the measured number, compound 3's estimate is 1.4-fold (0.14 log units) below it; the measured number falls inside the stated range.
By their numbers in this assay, from the lowest: compounds 2, 3 and 1 (each within the scatter of the next).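

In this assay, among these compounds, the first reading for fluorine at this place is a 1.4-fold higher number from compound 2 to compound 3 (0.14 log units; within the scatter), so 3,5-difluorophenyl and phenyl on the carbonyl carbon cannot be told apart. The exchange against the larger aryl group gives a 1.1-fold lower number from compound 1 to compound 3 (0.04 log units; within the scatter), which also lies within the scatter, so phenyl, naphthalen-2-yl and 3,5-difluorophenyl on this carbon form a single group of compounds with no order among them in this assay. The series therefore shows no measurable dependence on these aryl exchanges, and nothing at hand offers an explanation for that result.

Still open, going by these compounds, is whether any group on this carbonyl carbon can move the number beyond the scatter, and a phenyl ring carrying an amine or a carboxylic acid, or a longer chain in place of the ring, would test that. Among the compounds shown here, also open is whether fluorine on the ring in a pattern other than 3,5-difluorophenyl would read the same as compound 3 does, since only this one fluorinated ring appears.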